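A few compounds are considered here, and "the series" means these few. Any claim that something is new, unique, unknown or untested is made for them only; others in the source may bear on it.

In a functional assay on U-937 cells (Homo sapiens) for inhibition, read by MTT assay, with a stated time of 48 h (on this read-out higher numbers stand for weaker inhibition and lower numbers for stronger inhibition), three compounds sharing one core have been measured. Compound 1 (`O=C(CCCCOc1no[n+]([O-])c1S(=O)(=O)c1ccccc1)NO`) gives 2910 nM, compound 2 (`O=C(COCCOc1no[n+]([O-])c1S(=O)(=O)c1ccccc1)NO`) gives 8150 nM and compound 3 (`CC(C)(COc1no[n+]([O-])c1S(=O)(=O)c1ccccc1)C(=O)NO`) gives 12500 nM. Compound 3 cannot be separated from compound 2, since a 1.5-fold higher number from compound 2 to compound 3 (0.19 log units; within the scatter) lies within the scatter. It is clearly apart only from compound 1, as a 4.3-fold higher number from compound 1 to compound 3 (0.63 log units; beyond the scatter) lies beyond the scatter.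

Compound 4 (`O=C(/C=C/COc1no[n+]([O-])c1S(=O)(=O)c1ccccc1)NO`) changes the side chain of compound 3: 2-(hydroxycarbamoyl)ethenyl in place of 1-(hydroxycarbamoyl)-1-methylethyl on a saturated chain carbon bound to an oxygen on an aromatic ring. In words, 2-(hydroxycarbamoyl)ethenyl stands in place of 1-(hydroxycarbamoyl)-1-methylethyl on a saturated chain carbon bound to an oxygen on an aromatic ring.

Among the compounds with values here, no measured step makes this exact change, so the evidence is indirect. The chain of compound 1 also lacks the methyl branches of compound 3, and that pair shows a 4.3-fold higher number from compound 1 to compound 3 (0.63 log units; beyond the scatter). Compound 2 lacks them too, yet it shows only a 1.5-fold higher number from compound 2 to compound 3 (0.19 log units; within the scatter), and a 2.8-fold higher number from compound 1 to compound 2 (0.45 log units; beyond the scatter) shows that unbranched chains can differ from one another. A modest move to a lower number therefore seems likely, with the size uncertain. The expected change is a 2.1-fold lower number from compound 3 to compound 4 (0.32 log units; beyond the scatter). Compound 4 is estimated at 6000 nM, with an expected range of 2200 nM to 14000 nM.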

Compound 4, half-maximal inhibitory concentration: 48000 nM
Beside the measured number, compound 4's estimate is 8.0-fold (0.90 log units) below it; measured number outside the range, above it.
By their numbers in this assay, from the lowest: compound 1; then compounds 2 and 3 (each within the scatter of the next); then compound 4.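

In this assay, the 2-(hydroxycarbamoyl)ethenyl chain gives the weakest inhibition of the four compounds, with a 3.8-fold higher number from compound 3 to compound 4 (0.58 log units; beyond the scatter), a 5.9-fold higher number from compound 2 to compound 4 (0.77 log units; beyond the scatter) and a 16-fold higher number from compound 1 to compound 4 (1.22 log units; beyond the scatter), the last being the largest step in the series. The earlier compounds shown here had suggested that unbranched chains at this position sit at the stronger end or level with the branched one, but compound 4 is unbranched and goes against that pattern: losing the two methyl branches does not by itself bring a lower number, and the double bond-bearing chain lies beyond the scatter of all three saturated chains. No supporting measurement bears on why this change weakens inhibition, so the result stands as an observation only.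

The compounds shown leave open whether the loss comes from the double bond or from the shorter chain, since compound 4 differs from compound 1 in both, and a saturated chain of the same length as in compound 4 or a longer chain carrying the double bond would separate the two. They also leave open how a carboxylic acid in place of the hydroxycarbamoyl group would read on any of these chains.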